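This account rests on a few compounds, and the source may have more. Where it says the series, first, only, none or still open, it means among the compounds named here.

Compound 1 `Oc1ccc(-c2cc(-c3cccnc3)nc(-c3ccccc3Cl)c2)cc1` belongs to a small set of analogues built on a shared core that carries a 4-hydroxyphenyl group, a chlorophenyl group and a further aromatic ring. For cytotoxicity in an ADME assay on HEK293 cells (Homo sapiens) for cytotoxicity, read by CCK-8 assay and cell counting, with a stated time of 2 days (a higher number here means a weaker inhibitor, a lower number a stronger inhibitor), compound 1 is recorded as "not determined" (no result reported), so no number stands for it, and in this assay compound 3 `Oc1ccc(-c2cc(-c3ccncc3)nc(-c3ccc(Cl)cc3)c2)cc1` is likewise recorded as "not determined" (no result reported). Within the data shown here, the only measured member of the set is compound 2 `Oc1ccc(-c2cc(-c3ccsc3)nc(-c3cccc(Cl)c3)c2)cc1`, which in this assay gives 2670 nM. Compound 4 `Oc1ccc(-c2cc(-c3ccco3)nc(-c3ccccc3Cl)c2)cc1` has not yet been tested. It differs from compound 1 in one place: furan-2-yl in place of pyridin-3-yl on an aromatic carbon. Among the measured compounds shown here, since compound 1 has no number of its own, no step can be computed for this change, and the only anchor is the value of compound 2, whose structure differs from compound 4 in more than one place. For the measured compounds named here, on that basis the account expects no step beyond the usual scatter in this assay between compound 4 and the one measured analogue, with the true value possibly lying anywhere within a broad band around it. Compound 4 is therefore estimated to give 3000 nM in this assay, within a range from 700 nM to 13000 nM.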

Compound 4, half-maximal inhibitory concentration: 4310 nM
Beside the measured number, compound 4's estimate is 1.4-fold (0.16 log units) below it; the measured number falls inside the stated range.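

In this assay, among these compounds, compound 1 stands as "not determined" (no result reported), so no step from compound 1 to compound 4 can be read. The compounds shown leave open what replacing pyridin-3-yl with furan-2-yl does to the value in this assay. Nothing shown offers an explanation for the result of compound 4.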